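Halogen swap on the benzyl amide of the indazole series

This account rests on a few compounds, and the source may have more. Where it says the series, first, only, none or still open, it means among the compounds named here.

Two compounds of the shared core have numbers in a functional assay on A2780 cells (Homo sapiens) for antiproliferative activity, read by resazurin assay, with a stated time of 72 h (a lower number here means a stronger inhibitor, a higher number a weaker inhibitor), so far. Compound 1 `CN(C(=O)c1cc2c(Cc3ccccc3)n[nH]c2cc1O)c1ccco1` gives 2500 nM; compound 2 `CN(Cc1ccccc1Br)C(=O)c1cc2c(Cc3ccccc3)n[nH]c2cc1O` gives 1200 nM. Going by the values given here, compound 2 therefore stands lowest of the two, the one step recorded being a 2.1-fold lower number from compound 1 to compound 2 (0.32 log units; beyond the scatter), which placed 2-bromobenzyl in place of furan-2-yl on the amide-type nitrogen.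

Compound 3 `CN(Cc1ccc(F)cc1)C(=O)c1cc2c(Cc3ccccc3)n[nH]c2cc1O` differs from compound 2 by 4-fluorophenyl in place of 2-bromophenyl on a saturated chain carbon bound to an amide-type nitrogen. Among the compounds with values here, no measured step exchanges one substituted phenyl for another on the benzyl arm; the step from compound 1 to compound 2 changed the whole group on the nitrogen, so it does not bear on a halogen swap and gives no direction to lean on. With the benzyl arm kept, the expectation is a step of a 1.3-fold higher number from compound 2 to compound 3 (0.10 log units; within the scatter), not beyond the scatter. Compound 3 is thus estimated at 1500 nM in this assay, with a range from 600 nM to 4000 nM.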

Compound 3, half-maximal inhibitory concentration: 4100 nM
Beside the measured number, compound 3's estimate is 2.7-fold (0.44 log units) below it; measured number outside the range, above it.
By their numbers in this assay, from the lowest: compound 2; then compounds 1 and 3 (each within the scatter of the next).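

On the benzyl arm the substituted phenyl matters: in this assay, 4-fluorophenyl in place of 2-bromophenyl on a saturated chain carbon bound to an amide-type nitrogen gives a step beyond the scatter (a 3.4-fold higher number from compound 2 to compound 3 (0.53 log units; beyond the scatter)), so keeping the benzyl arm does not by itself keep the number of compound 2. The 4-fluorobenzyl group stays within the scatter of furan-2-yl (a 1.6-fold higher number from compound 1 to compound 3 (0.21 log units; within the scatter)), so of the two benzyl groups shown, only 2-bromobenzyl stands apart from furan-2-yl. No evidence on the reason for this difference is available.

The halogen and its place on the ring change together in this step, so their shares cannot be separated. On these data alone, how 2-fluorobenzyl, 4-bromobenzyl or unsubstituted benzyl would sit remains open.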